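Cytotoxicity of a Boron-Containing Amide Series

The compounds below may be only part of what the source reports. "The series", "measured", "known", "first", "only" and "open" are said of these compounds alone.

Compound 1 `CCNC(=O)CCc1cccc2c1B(O)OC2` is the simplest member of this small set of amides built on a shared core. In an ADME assay on WI-38 cells (Homo sapiens) for cytotoxicity, read by MTT assay, with a stated time of 72 h (on this read-out higher numbers stand for weaker inhibition and lower numbers for stronger inhibition), compound 1 gives > 100000 nM, which is a limit of the assay rather than a measured number, so compound 1 stands at the top of the numbers shown. Compound 2 `CC(C)(C)OC(=O)NCc1ccc(NC(=O)CCc2cccc3c2B(O)OC3)cc1` gives 4800 nM in this assay, and compound 3 `O=C(CCc1cccc2c1B(O)OC2)Nc1cccc(Br)c1` gives 20000 nM. Compound 4 `O=C(CCc1cccc2c1B(O)OC2)Nc1cccc(I)c1` has not yet been measured. Compared with compound 1, compound 4 carries 3-iodophenyl in place of ethyl on an amide-type nitrogen.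

Among the compounds with values here, the measured step that bears on this change is the one from compound 1 to compound 3, where an at least 5.0-fold lower number from compound 1 to compound 3 (0.69 log units; beyond the scatter). Since 3-iodophenyl and 3-bromophenyl are close in kind, and because compound 1 sits at the limit of > 100000 nM in this assay, at which 1 of the 3 values shown sits, a step of similar size and direction is expected for compound 4, with the estimated change being an at least 5.5-fold lower number from compound 1 to compound 4 (0.74 log units; beyond the scatter). The estimated value for compound 4 is therefore 18000 nM, with a range from 6000 nM to 50000 nM.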

Compound 4, half-maximal inhibitory concentration: 71000 nM
For compound 4 the middle estimate is 3.9-fold (0.60 log units) below the measured one; measured number above the stated range.
By their numbers in this assay, from the lowest: compound 2; then compound 3; then compound 4. At a limit, above all of these: compound 1.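

In this assay the change to iodo in place of bromo on an aromatic carbon gives a 3.6-fold higher number from compound 3 to compound 4 (0.55 log units; beyond the scatter) and so the two halogens are not interchangeable on this aryl amide. The 3-iodophenyl group in place of ethyl on the amide nitrogen gives an at least 1.4-fold lower number from compound 1 to compound 4 (0.14 log units; that floor lies within the scatter) and so, unlike the 3-bromophenyl group, it shows no change that clears the usual scatter. That step can be read only as a floor because compound 1 has a limit rather than a number: the limit of > 100000 nM in this assay, at which 1 of the 4 values shown sits.

Going by these compounds, whether a plain phenyl or a 3-chlorophenyl group on the same amide nitrogen would sit nearer to compound 3 or to compound 4 stays open. The compounds shown also cannot tell why the iodo and bromo compounds differ.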